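Aryl swaps on the amide nitrogen of a shared core

This account rests on a few compounds, and the source may have more. Where it says the series, first, only, none or still open, it means among the compounds named here.

Measured so far, in an assay on isolated protein for inhibition of histone deacetylase 4 (Homo sapiens), with a stated time of 1 h; on this read-out higher numbers stand for weaker inhibition and lower numbers for stronger inhibition:
- compound 1 `Cc1ccc(NC(=O)COc2ccc3cc(/C=C4/SC(=O)NC4=O)ccc3c2)cc1`: compound 1 gives 1700 nM
- compound 2 `CCOc1ccc2nc(NC(=O)COc3ccc4cc(/C=C5/SC(=O)NC5=O)ccc4c3)sc2c1`: compound 2 gives 3600 nM
- compound 3 `O=C(COc1ccc2cc(/C=C3/SC(=O)NC3=O)ccc2c1)Nc1ccccn1`: compound 3 gives 17000 nM

Compound 3 stands highest of the three numbers in this assay, with compound 2 nearest and compound 1 furthest; both gaps lie beyond the scatter. Within the data shown here, only one measured step is of the same kind as the change considered below, and it is a 10-fold higher number from compound 1 to compound 3 (1.00 log units; beyond the scatter), a modest step that set the pyridin-2-yl group apart from an aromatic ring of carbon only on the amide-type nitrogen.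

Compound 4 `O=C(COc1ccc2cc(/C=C3/SC(=O)NC3=O)ccc2c1)Nc1ccc(F)cc1F` differs from compound 3 by 2,4-difluorophenyl in place of pyridin-2-yl on an amide-type nitrogen. This puts back a six-membered aromatic ring of carbon only in the position that in compound 1 carried 4-methylphenyl. Nothing measured speaks to the two fluorine atoms themselves. On the strength of the step from compound 1 to compound 3 alone, compound 4 is expected to show a 5.7-fold lower number from compound 3 to compound 4 (0.75 log units; beyond the scatter), a lower number of a size near that step, held with caution. The estimate for compound 4 in this assay is therefore 3000 nM, between 1000 nM and 10000 nM.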

Compound 4, half-maximal inhibitory concentration: 3900 nM
For compound 4 the middle estimate is 1.3-fold (0.11 log units) below the measured one, within the range that was stated.
By their numbers in this assay, from the lowest: compound 1; then compounds 2 and 4 (each within the scatter of the next); then compound 3.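

In this assay, replacing pyridin-2-yl with a second six-membered aromatic ring of carbon only gives a 4.4-fold lower number from compound 3 to compound 4 (0.64 log units; beyond the scatter), so the high number of compound 3 no longer rests on the comparison with 4-methylphenyl alone: among the groups shown on this amide-type nitrogen, pyridin-2-yl gives the weakest inhibition, against both rings of carbon only. Among these compounds, those two rings are not interchangeable either, with a 2.3-fold higher number from compound 1 to compound 4 (0.36 log units; beyond the scatter), so the position responds to what the ring carries as well as to whether the ring holds a nitrogen, although this modest step involves only one pair of substituent patterns. No measurement at hand bears on the reason for either step.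

With only 4-methylphenyl and 2,4-difluorophenyl as rings of carbon only, the contribution of each fluorine atom cannot be separated from that of the ring, and plain phenyl or a ring carrying a single fluorine atom would be needed to tell them apart. Also open, going by these compounds, is how this nitrogen tolerates a carboxylic acid or an amine on the ring, or a saturated ring such as cyclohexyl in place of the aromatic one.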